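The source may report more compounds than this note shows. Statements on the series, on what has been measured and on what is new or still open speak of the compounds shown alone.

Compound 1 `CC(C)c1noc(N2CCC(Oc3cc(N4CCc5cc([S+]([O-])CCO)ccc54)ncn3)CC2)n1` gives 2.7 in a physicochemical assay for lipophilicity, measured as octanol-water partition, at pH 7.4; on this read-out lower numbers stand for lower lipophilicity and higher numbers for higher lipophilicity. Compound 2 `CC(C)c1noc(N2CCC(Oc3cc(N4CCc5cc(S(C)(=O)=O)ccc54)ncn3)CC2)n1` gives 3.1. Compound 3 `CC(=O)N(C)c1ccc2c(c1)CCN2c1cc(OC2CCN(c3nc(C(C)C)no3)CC2)ncn1` gives 3.7.

Among these three, compound 3 stands highest, with compound 2 nearest, a number 0.60 log units higher from compound 2 to compound 3 (beyond the scatter), and compound 1 furthest, a number 1.00 log units higher from compound 1 to compound 3 (beyond the scatter). Compound 4 `CC(C)c1noc(N2CCC(Oc3cc(N4CCc5cc(N6CCOCC6=O)ccc54)ncn3)CC2)n1` has not yet been measured in this assay. It differs from compound 3 in one place: 3-oxomorpholin-4-yl in place of acetyl(methyl)amino on an aromatic carbon.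

Among the compounds with values here, none of the measured steps swaps an acyclic amide for a cyclic one, so no step bears on this change directly. The steps that come closest are those leading into compound 3: the change of methylsulfonyl to acetyl(methyl)amino, a number 0.60 log units higher from compound 2 to compound 3 (beyond the scatter), and the change from the sulfoxide-bearing group of compound 1, a number 1.00 log units higher from compound 1 to compound 3 (beyond the scatter). Both show that exchanging one group on this aromatic carbon moves the number by a modest amount. The entering 3-oxomorpholin-4-yl keeps the amide of the leaving group and adds a second hydrogen-bond acceptor within a six-membered ring, so a modest step downward from compound 3 is expected rather than an upward one. The expected step is a number 0.40 log units lower from compound 3 to compound 4 (beyond the scatter). For compound 4 the estimate in this assay is 3.3, with a range from 2.8 to 3.8.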

Compound 4, distribution coefficient: 3.1
Beside the measured number, compound 4's estimate is 0.20 log units above it, within the range that was stated.
By their numbers in this assay, from the lowest: compound 1; then compounds 2 and 4 (each within the scatter of the next); then compound 3.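

In this assay the change to 3-oxomorpholin-4-yl on this aromatic carbon gives a number 0.60 log units lower from compound 3 to compound 4 (beyond the scatter) and thus shows that an amide held in a six-membered ring with 2 hetero atoms does not keep the number of the open acetyl(methyl)amino group. The other two comparisons place the new group among those already seen at this position: against methylsulfonyl there is no change at the digits printed from compound 2 to compound 4 (within the scatter) and against the group of compound 1 there is a number 0.40 log units higher from compound 1 to compound 4 (beyond the scatter) and so, of the four groups shown here, acetyl(methyl)amino gives the highest number and the group of compound 1 the lowest. Nothing available here explains why these groups differ in this way.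

From the compounds shown here alone, what remains open is whether the step from compound 3 follows from the ring itself or from the ring oxygen, which a piperidin-2-one at this carbon would help to separate. Also open, going by these compounds, is how the number would move with a secondary amide, a primary amine or a carboxylic acid at this position.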